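This account rests on a few compounds, and the source may have more. Where it says the series, first, only, none or still open, it means among the compounds named here.

Compound 1, `C=CCCn1c(=O)c2[nH]cnc2n(CCC)c1=O`, gives 60 nM in an assay on Cerebral cortex for binding affinity to adenosine receptor A1 (Cavia porcellus), read by radioligand binding; a higher number here means a weaker inhibitor, a lower number a stronger inhibitor.
Compound 2, `CCCn1c(=O)n(CCOC)c(=O)c2[nH]cnc21`, gives 2500 nM in this assay.
Compound 3, `CCCn1c(=O)n(C)c(=O)c2c1ncn2CC(N)=O`, gives > 200000 nM in this assay; this is a limit of the assay, not a number.

Compound 3 thus stands at the limit of > 200000 nM in this assay, at which 1 of the 3 values shown sits, the weakest end of what this assay reports, and no number is known for it. Compound 4, `CCCn1c(=O)n(C)c(=O)c2c1ncn2CCO`, differs from compound 3 by hydroxymethyl in place of carbamoyl on a saturated chain carbon bound to an aromatic nitrogen. Of the measured steps none concerns this exchange: a 42-fold higher number from compound 1 to compound 2 (1.62 log units; beyond the scatter) changes another chain on the shared core and gives no guide here. The expectation is therefore a step of an at least 2.0-fold lower number from compound 3 to compound 4 (0.30 log units; that floor lies within the scatter), uncertain in direction, with a fair chance that this assay again returns only a limit. Compound 4 is estimated at 100000 nM, with a range from 20000 nM to 500000 nM.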

Compound 4, inhibition constant: 41400 nM
Compound 4: the middle estimate sits 2.4-fold (0.38 log units) above what was measured; measured number inside the range.
By their numbers in this assay, from the lowest: compound 1; then compound 2; then compound 4. At a limit, above all of these: compound 3.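

Among these compounds, on the saturated chain carbon bound to an aromatic nitrogen, hydroxymethyl in place of carbamoyl gives an at least 4.8-fold lower number from compound 3 to compound 4 (0.68 log units; beyond the scatter), the first measured change at this position. In this assay, compound 4 gives 41400 nM, so the 2-hydroxyethyl chain returns a number on this core. Compound 3 gives > 200000 nM, a limit and not a number, so the step is only a floor: the limit of > 200000 nM in this assay, at which 1 of the 4 values shown sits.

As far as these compounds go, how far the true step exceeds that floor stays open. Also open, from the compounds shown here alone, is whether an amine, a carboxylic acid or a longer chain at this position would move the number further.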